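The source may report more compounds than this note shows. Statements on the series, on what has been measured and on what is new or still open speak of the compounds shown alone.

Compound 2 `COc1ccc(C(=O)C2=C(O)C(=O)N(c3ccc(-c4nc(C)no4)cc3)C2C2CCCCC2)cc1` is the lower of the two compounds measured in an ADME assay on the whole organism for pharmacokinetics, with Rattus norvegicus as the target; on this read-out lower numbers stand for slow clearance and higher numbers for fast clearance. Compound 2 gives 3.4 mL/min/kg, whereas compound 1 `CCOC(=O)c1ccc(N2C(=O)C(O)=C(C(=O)c3ccc(OC)cc3)C2c2ccc(F)cc2)cc1` gives 37 mL/min/kg, a gap that is beyond the scatter of this assay. Compound 3 `COc1ccc(C(=O)C2=C(O)C(=O)N(c3ccc(-c4cc(C)no4)cc3)C2C2CCCCC2)cc1` is the next compound in this series and has not yet been measured. It differs from compound 2 in one place: 3-methyl-1,2-oxazol-5-yl in place of 3-methyl-1,2,4-oxadiazol-5-yl on an aromatic carbon. For the measured compounds named here, no pair of measured compounds shows what such a change does to clearance, so the direction of the step cannot be read from the measured data. With a change of this kind, in which the group that leaves and the group that enters are of the same size and sit in the same place, the step expected from compound 2 to compound 3 in this assay is a 1.3-fold higher number from compound 2 to compound 3 (0.12 log units; within the scatter), which is none beyond the scatter. Compound 3 is therefore estimated to give 4.5 mL/min/kg in this assay, within a range from 2 mL/min/kg to 10 mL/min/kg.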

Compound 3, clearance: 6.2 mL/min/kg
The estimate for compound 3 lay 1.4-fold (0.14 log units) below the measured number; measured number inside the range.
By their numbers in this assay, from the lowest: compounds 2 and 3 (each within the scatter of the next); then compound 1.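

In this assay, for the compounds shown here, the change from 3-methyl-1,2,4-oxadiazol-5-yl to 3-methyl-1,2-oxazol-5-yl on an aromatic carbon gives a 1.8-fold higher number from compound 2 to compound 3 (0.26 log units; within the scatter) and is the first step at this position that can be read. It shows that, on this read-out, the five-membered aromatic ring with 3 hetero atoms and 3 hydrogen-bond acceptors cannot be told apart from the one with 2 hetero atoms and 2 hydrogen-bond acceptors. No measured evidence bears on this result. The compounds shown leave open whether a group outside this pair of rings, such as a nitrile or a carboxylic acid, would keep clearance in this range at the same place. They also leave open whether this step would hold on the core of compound 1, which differs from compound 2 in more than one place.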